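This account rests on a few compounds, and the source may have more. Where it says the series, first, only, none or still open, it means among the compounds named here.

Compound 1: `O=C(O)Cc1sc(C(c2ccc(F)cc2)c2ccc(F)cc2)nc1-c1ccnc(F)c1`, which in an in vitro functional assay on HEK285-7 cells for antagonist activity at prostaglandin D2 receptor 2 (Homo sapiens), read by BRET and beta-arrestin recruitment (a lower number here means a smaller maximal response, a higher number a larger maximal response), gives 80%.
Compound 2: `COc1cc(-c2nc(C(c3ccc(F)cc3)c3ccc(F)cc3)sc2CC(=O)O)ccn1`, which gives 60%.
Compound 3: `O=C(O)Cc1sc(C(c2ccc(F)cc2)c2ccc(F)cc2)nc1-c1ccnc(Cl)c1`, which gives 80%.

Compound 3 stands level with compound 1, since no change at the digits printed from compound 1 to compound 3 (within the scatter), and together these two hold the highest numbers of the three. Compound 2 lies furthest from compound 3, as shown by a number 20 percentage points higher from compound 2 to compound 3 (beyond the scatter). The only other move of size among the measured compounds is a number 20 percentage points lower from compound 1 to compound 2 (beyond the scatter), where methoxy replaced fluoro.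

Compound 4, `O=C(O)Cc1sc(C(c2ccc(F)cc2)c2ccc(F)cc2)nc1-c1ccnc(O)c1`, has not yet been measured. Compared with compound 3 it shows (hydroxy in place of chloro on an aromatic carbon). Among the compounds with values here, no measured step swaps chloro for hydroxy directly, so the nearest guides are the two steps that involve methoxy: a number 20 percentage points lower from compound 1 to compound 2 (beyond the scatter) and a number 20 percentage points higher from compound 2 to compound 3 (beyond the scatter). The hydroxy group of compound 4 resembles the methoxy group of compound 2 more than it resembles chloro or fluoro, so a modest fall is expected rather than no change, though the match is loose and the range is kept wide. The expected step is a number 15 percentage points lower from compound 3 to compound 4 (beyond the scatter). Compound 4 is therefore estimated to give 65%, with a range from 45% to 85%.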

Compound 4, largest response reached (reported as efficacy), in percent of the reference or control that the assay uses: 60%
The estimate for compound 4 lay 5 percentage points above the measured number, within the range that was stated.
By their numbers in this assay, from the lowest: compounds 2 and 4 (each within the scatter of the next); then compounds 1 and 3 (each within the scatter of the next).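

Hydroxy at this aromatic carbon next to the ring nitrogen shows that the drop seen with methoxy is not a one-off. In this assay, there is a number 20 percentage points lower from compound 3 to compound 4 (beyond the scatter) and likewise a number 20 percentage points lower from compound 1 to compound 4 (beyond the scatter), so either halogen gives way to hydroxy with a step of the same size as the one seen for methoxy. Taking the methyl off the oxygen leaves no change at the digits printed from compound 2 to compound 4 (within the scatter), so across these four compounds the lower level does not depend on that methyl, and the compounds fall into two groups, the chloro and fluoro pair and the hydroxy and methoxy pair, with none going against this split. No outside evidence is available to say what lies behind this split.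

Still open, from the compounds shown here alone, is whether an amine or a plain hydrogen at this carbon would sit with the halogens or with the oxygen-linked groups. A longer chain on the oxygen, such as ethoxy, could also test whether the level stays the same once the group grows beyond methoxy.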